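The source may report more compounds than this note shows. Statements on the series, on what has been measured and on what is new or still open speak of the compounds shown alone.

Measured so far in a functional assay on HCT-116 cells (Homo sapiens) for cytotoxicity, read by sulforhodamine B assay, with stated times of 4 h and 5 days; a lower number here means a stronger inhibitor, a higher number a weaker inhibitor:
Compound 1 `O=[N+]([O-])c1cn(CS(=O)(=O)NCCO)cn1`, for which only a limit of this assay is recorded: > 6000000 nM
Compound 2 `O=[N+]([O-])c1cncn1CCS(=O)(=O)NCCO`: 5300000 nM
Compound 3 `Cc1ncc([N+](=O)[O-])n1CCS(=O)(=O)NCCO`: 400000 nM

Compound 3 gives the lowest of the two numbers in this assay. Within the data shown here, its nearest neighbour is compound 2, and the single measured step, a 13-fold lower number from compound 2 to compound 3 (1.12 log units; beyond the scatter), lies beyond the scatter. Compound 1 sits at the limit of > 6000000 nM in this assay, at which 1 of the 3 values shown sits, and offers no number for comparison.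

Compound 4 `Cc1ncc([N+](=O)[O-])n1CCS(=O)(=O)N1CCOCC1` differs from compound 3 by morpholin-4-yl in place of (2-hydroxyethyl)amino on a sulfonyl sulfur. Among the measured compounds shown here, no measured step alters the group on the sulfonyl sulfur; the one step recorded concerns a methyl entering on an aromatic carbon, and it says nothing about an exchange at the sulfonamide nitrogen. For the measured compounds named here, with no step bearing on this change, the working expectation is that this assay shows no difference beyond the scatter, and the estimate therefore stays close to the number for compound 3, which gives 400000 nM. For compound 4 the expected step is no change at the digits printed from compound 3 to compound 4 (within the scatter). Compound 4 is accordingly estimated at 400000 nM in this assay, with a range from 100000 nM to 1600000 nM that reflects the absence of any guiding step.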

Compound 4, half-maximal inhibitory concentration: 38000 nM
For compound 4 the middle estimate is 11-fold (1.02 log units) above the measured one; the measured number lies below the stated range.
By their numbers in this assay, from the lowest: compound 4; then compound 3; then compound 2. At a limit, above all of these: compound 1.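

The group on the sulfonyl sulfur is not a silent position in this assay: an 11-fold lower number from compound 3 to compound 4 (1.02 log units; beyond the scatter), so the series now holds a large step at this site as well as the one at the aromatic carbon, a 13-fold lower number from compound 2 to compound 3 (1.12 log units; beyond the scatter). The exchange of (2-hydroxyethyl)amino for morpholin-4-yl removes the hydrogen-bond donors of the leaving group and brings in a six-membered ring in a single move, and this one step cannot separate those two differences. Nothing measured here gives a property of either group that would account for the step.

Open, from the compounds shown here alone, is which feature carries the step: a piperidin-1-yl group would test the ring oxygen, while a (2-methoxyethyl)amino or dimethylamino group would test an open chain on the sulfonyl sulfur. Also open, going by these compounds, is whether morpholin-4-yl gives a step of similar size on the core of compound 2, which lacks the methyl, and so whether the two large steps add or overlap.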